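Butoxycarbonyl to (ethylsulfanyl)carbonyl: series notes

This account rests on a few compounds, and the source may have more. Where it says the series, first, only, none or still open, it means among the compounds named here.

Three compounds of the series carry numbers in a functional assay on CHO-K1 cells for agonist activity at Glucose-dependent insulinotropic receptor (Homo sapiens), read by a luciferase reporter, with a stated time of 5 h; a lower number here means that less compound is needed, a higher number that more compound is needed for the effect:

compound 1, `CC(C)(C)OC(=O)N1CCC(Oc2cccc3c2CCN3c2ccc(S(C)(=O)=O)cc2)CC1`, gives 158 nM
compound 2, `CC(C)OC(=O)N1CCC(Oc2cccc3c2CCN3c2ccc(S(C)(=O)=O)cc2F)CC1`, gives 1000 nM
compound 3, `CCCCOC(=O)N1CCC(Oc2ncnc3c2CCN3c2ccc(S(C)(=O)=O)cc2F)CC1`, gives 50.1 nM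

Compound 3 stands at the lowest number of the three. Its nearest neighbour is compound 1, a step higher that lies beyond the scatter; compound 2 is furthest, again beyond the scatter. No two of these compounds differ in one place only, so no single step can be read off from the measured set.

Compound 4, `CCSC(=O)N1CCC(Oc2ncnc3c2CCN3c2ccc(S(C)(=O)=O)cc2F)CC1`, is not yet measured. It departs from compound 3 by ethylsulfanyl in place of butoxy on a carbonyl carbon; cut one bond further out, the change reads butoxycarbonyl to (ethylsulfanyl)carbonyl. Nothing measured speaks directly to this exchange: none of the three measured compounds carries sulfur on that carbonyl carbon, and they differ from one another in several places at once. The expected step is a 2.4-fold higher number from compound 3 to compound 4 (0.38 log units; beyond the scatter), a rise that may or may not clear the scatter. Compound 4 is estimated at 120 nM, with a range from 40 nM to 400 nM.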

Compound 4, half-maximal effective concentration: 31.6 nM
The estimate for compound 4 lay 3.8-fold (0.58 log units) above the measured number, and the stated range ends above it.
By their numbers in this assay, from the lowest: compounds 4 and 3 (each within the scatter of the next); then compound 1; then compound 2.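

Going by these compounds alone, compound 3 and compound 4 form the first pair that differs in one place only, and the step, a 1.6-fold lower number from compound 3 to compound 4 (0.20 log units; within the scatter), gives a first direct reading in this assay for the group on the carbonyl carbon whose other neighbour is the amide-type nitrogen in a ring. The two compounds cannot be told apart in this assay, so this place accepts ethylsulfanyl in place of butoxy with no change that can be read, even though sulfur replaces oxygen and the chain differs as well. Nothing in hand accounts for the two numbers staying together.

The exchange alters the bonded atom and the chain at once, so this one pair cannot separate the two; ethoxy and butylsulfanyl on the same carbonyl carbon would pull them apart, and a diethylamino group would show whether a nitrogen is accepted there too. From the compounds shown here alone, whether ethylsulfanyl behaves in the same way on the core of compound 1 or of compound 2 also stays open, as does the behaviour of this pair in any other assay.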